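One methoxy group removed, in two compound pairs

A few compounds are considered here, and "the series" means these few. Any claim that something is new, unique, unknown or untested is made for them only; others in the source may bear on it.

Measured compounds in a functional assay on UO-31 cells (Homo sapiens) for cytotoxicity, read by sulforhodamine B assay, with a stated time of 48 h, tested at 1 uM; on this read-out lower numbers stand for a stronger effect and higher numbers for a weaker effect at the one concentration tested:
compound 1, `COc1cc(-c2cc(/C=C/C(=O)c3ccc(N)cc3)[nH]n2)cc(OC)c1OC`: 71%
compound 2, `COc1ccc(-c2cc(/C=C/C(=O)c3ccc(N)cc3)[nH]n2)cc1OC`: 86%
compound 3, `COc1cc(C(=O)/C=C/c2cc(-c3cc(OC)c(OC)c(OC)c3)n[nH]2)cc(OC)c1OC`: 62%

The change from compound 1 to compound 2 is hydrogen in place of methoxy on an aromatic carbon. It made a number 15 percentage points higher from compound 1 to compound 2 (beyond the scatter). Compound 4, `COc1ccc(-c2cc(/C=C/C(=O)c3cc(OC)c(OC)c(OC)c3)[nH]n2)cc1OC`, has not yet been measured; it differs from compound 3 by hydrogen in place of methoxy on an aromatic carbon, the same change, and the surroundings of the place are described in the same words for both pairs. The difference between the core of compound 1 and the core of compound 3 is not broken down here. Compound 3 and compound 1 lie within the scatter of each other, while compound 2 stands beyond the scatter from compound 3.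

Within the data shown here, the expectation for compound 4 rests on the one measured step of this change, a number 15 percentage points higher from compound 1 to compound 2 (beyond the scatter). Compound 4 is therefore expected to give 77% in this assay, with a likely range from 64% to 90%. Among the measured compounds shown here, the expected step is a number 15 percentage points higher from compound 3 to compound 4 (beyond the scatter), matching the earlier one; only a single measured pair supports this, so the range is kept wide.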

Compound 4, a percentage reported as activity, at one concentration (the size of the read-out at that concentration, not a potency): 67%
Compound 4: middle estimate off by 10 percentage points, on the high side, within the range that was stated.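

In this assay, among these compounds, hydrogen in place of methoxy on an aromatic carbon gave a number 5 percentage points higher from compound 3 to compound 4 (within the scatter), so on this core the change produced no step that can be told from the scatter. Set beside the earlier pair, the two steps do not separate: the same change on two cores in this assay, a number 15 percentage points higher (beyond the scatter) from compound 1 to compound 2 and a number 5 percentage points higher (within the scatter) from compound 3 to compound 4, 10 percentage points apart, within the scatter of two such steps. Among the compounds shown here, this shows no measurable difference between the two cores in what the change does, but it does not show that the step carries over unchanged, as only one of the two steps lies beyond the scatter and two pairs tested at one concentration are a thin base for any rule.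

The compounds shown leave open what a hydroxyl group, a chlorine atom or a longer alkoxy chain would do in place of the methoxy at this position. They also leave open whether a carboxylic acid on the ring that carries the carbonyl would alter the size of the step.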